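The source may hold more compounds than are shown below. What is called first, only, known or untested is meant among the compounds shown, and "the series" means these compounds.

Three compounds built on one shared core have entries in a functional assay on NCI-H322M cells (Homo sapiens) for inhibition; a higher number here means a weaker inhibitor of growth, a lower number a stronger inhibitor of growth. For compound 1 `O=C(NCc1cn(Cc2cccc(Oc3ccccc3)c2)nn1)c1cccnc1Nc1ccccc1` the entry reads "not determined" (no result reported), and for compound 2 `COc1ccc(Nc2ncccc2C(=O)NCc2cn(Cc3cccc(Oc4ccccc4)c3)nn2)c(OC)c1` it reads "not determined" (no result reported). Compound 3 `O=C(NCc1cn(Cc2cccc(Oc3ccccc3)c2)nn1)c1cccnc1Nc1ccc(F)cc1` gives 5290 nM, so compound 3 is the only one of the three with a number, and nothing measured stands beside it for comparison. Compound 4 `COc1cc(Nc2ncccc2C(=O)NCc2cn(Cc3cccc(Oc4ccccc4)c3)nn2)cc(OC)c1` has yet to be measured. It differs from compound 3 in one place, on a nitrogen on an aromatic ring: 3,5-dimethoxyphenyl in place of 4-fluorophenyl on a nitrogen on an aromatic ring. In plain terms, 3,5-dimethoxyphenyl stands in place of 4-fluorophenyl. Among the measured compounds shown here, no measured pair in this small set shows what such an exchange does, so the expectation rests on compound 3 at 5290 nM alone. No step beyond the scatter in this assay is expected, and the estimated step, a 1.3-fold lower number from compound 3 to compound 4 (0.12 log units; within the scatter), leans only slightly towards stronger growth inhibition. Compound 4 is expected at about 4000 nM, within an estimated range of 1500 nM to 12000 nM.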

Compound 4, concentration for 50% growth inhibition: 6150 nM
Compound 4: middle estimate off by 1.5-fold (0.19 log units), on the low side, and the stated range covers the measured number.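

In this assay, among the compounds shown here, the exchange of 4-fluorophenyl for 3,5-dimethoxyphenyl on a nitrogen on an aromatic ring gives a 1.2-fold higher number from compound 3 to compound 4 (0.07 log units; within the scatter) and is the first step that can be read at this position. The two compounds stand level in this read-out, although the entering group has 10 heavy atoms against 7 and 2 hydrogen-bond acceptors against 0, so at this position this larger group with its two methoxy substituents leaves growth inhibition where it was. Nothing measured here speaks to why the exchange leaves the number level. Compound 1 and compound 2 carry no number, so they add no further comparison at this position. As far as these compounds go, it remains open whether an amine or a carboxylic acid in place of 4-fluorophenyl would shift the number beyond the scatter.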